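The source may hold more compounds than are shown below. What is called first, only, known or untested is meant among the compounds shown, and "the series" means these compounds.

Of the compounds shown here, three sharing a core have been measured in a functional assay on SMMC-7721 cells (Homo sapiens) for antiproliferative activity, read by MTT assay, with a stated time of 72 h; on this read-out higher numbers stand for weaker inhibition and lower numbers for stronger inhibition. Compound 1 `C/C(=N\NC(=O)c1cccc(S(=O)(=O)N2CCOCC2)c1)c1cc(Br)ccc1O` gives 2410 nM and compound 2 `C/C(=N\NC(=O)c1cccc(S(=O)(=O)N2CCOCC2)c1)c1cc(F)ccc1O` gives 1150 nM. Fluoro in place of bromo on an aromatic carbon accounts for a 2.1-fold lower number from compound 1 to compound 2 (0.32 log units; beyond the scatter), a modest step. Compound 3 `O=C(N/N=C/c1ccco1)c1cccc(S(=O)(=O)N2CCOCC2)c1` gives > 100000 nM, which is a limit of the assay and not a number. Compound 3 therefore stands at the limit of > 100000 nM in this assay, at which 1 of the 3 values shown sits.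

Compound 4 `O=C(N/N=C/c1cc(Br)cc(Br)c1O)c1cccc(S(=O)(=O)N2CCOCC2)c1` departs from compound 3 at one place, on a carbon with a double bond to nitrogen, where 3,5-dibromo-2-hydroxyphenyl takes the place of furan-2-yl: 3,5-dibromo-2-hydroxyphenyl in place of furan-2-yl on a carbon with a double bond to nitrogen. For the measured compounds named here, no measured step makes this exchange, so the evidence is indirect. Compound 1, at 2410 nM, and compound 2, at 1150 nM, both carry a halogen on a hydroxyphenyl group, as compound 4 does, and a 2.1-fold lower number from compound 1 to compound 2 (0.32 log units; beyond the scatter) suggests that the choice of halogen moves the number only modestly. A large step to a lower number in this assay is therefore expected, estimated as an at least 40-fold lower number from compound 3 to compound 4 (1.60 log units; beyond the scatter). Compound 4 is expected to give about 2500 nM, with an estimated range of 600 nM to 12000 nM.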

Compound 4, half-maximal inhibitory concentration: 7310 nM
Beside the measured number, compound 4's estimate is 2.9-fold (0.47 log units) below it; the measured number falls inside the stated range.
By their numbers in this assay, from the lowest: compound 2; then compound 1; then compound 4. At a limit, above all of these: compound 3.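

In this assay, 3,5-dibromo-2-hydroxyphenyl in place of furan-2-yl on a carbon with a double bond to nitrogen brings an at least 13-fold lower number from compound 3 to compound 4 (1.13 log units; beyond the scatter), a large step and the first measured one at this place, whereas the earlier step, a 2.1-fold lower number from compound 1 to compound 2 (0.32 log units; beyond the scatter), was a modest one that changed only a halogen. For the compounds shown here, the value of compound 3 is a limit of the assay and not a number, so this step fixes only the smallest size the change can have: the limit of > 100000 nM in this assay, at which 1 of the 4 values shown sits. Compound 4 differs from compound 1 and from compound 2 in more than one place, so no step from either of them to compound 4 can be read.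

On these data alone, what remains open is which part of the entering group carries the step: the six-membered aromatic ring, its hydroxy group or its bromine atoms. Also open, as far as these compounds go, is how this position would read with an unsubstituted phenyl, a pyridine, an amine-bearing ring or a short alkyl chain on the same carbon.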